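A larger aromatic group on the shared core

The source may report more compounds than this note shows. Statements on the series, on what has been measured and on what is new or still open speak of the compounds shown alone.

Measured in (a physicochemical assay for solubility, at pH 7; on this read-out higher numbers stand for higher solubility and lower numbers for lower solubility):
Compound 1 `CN1CCC(C(=O)N2Cc3c(NC(=O)C4CC4)n[nH]c3C2(C)C)CC1`: > 225000 nM (a limit, not a number)
Compound 2 `CN1CCC(C(=O)N2Cc3c(NC(=O)C4CCC4)n[nH]c3C2(C)C)CC1`: > 225000 nM (a limit, not a number)
Compound 3 `CN1CCC(C(=O)N2Cc3c(NC(=O)c4cccs4)n[nH]c3C2(C)C)CC1`: 155000 nM

Compound 3 alone has a true number. Compounds 1 and 2 sit at a limit (the limit of > 225000 nM in this assay, at which 2 of the 3 values shown sit).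

Compound 4 `CN1CCC(C(=O)N2Cc3c(NC(=O)c4ccc(C(F)(F)F)cc4)n[nH]c3C2(C)C)CC1` keeps the shared core, with 4-(trifluoromethyl)phenyl in place of thiophen-2-yl on a carbonyl carbon.

Going by the values given here, two measured steps bear on this, both bringing in thiophen-2-yl: (an at least 1.4-fold lower number from compound 1 to compound 3 (0.16 log units; that floor lies within the scatter)) and (an at least 1.4-fold lower number from compound 2 to compound 3 (0.16 log units; that floor lies within the scatter)). Neither swaps one aromatic ring for another, so they guide only loosely. A moderately lower number is expected in this assay (a 2.6-fold lower number from compound 3 to compound 4 (0.41 log units; beyond the scatter)). The estimated value for compound 4 is (60000 nM), with an expected range of (15000 nM to 170000 nM).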

Compound 4, solubility: 191000 nM
For compound 4 the middle estimate is 3.2-fold (0.50 log units) below the measured one; the measured number lies above the stated range.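

In this assay, 4-(trifluoromethyl)phenyl in place of thiophen-2-yl on the carbonyl carbon gives a 1.2-fold higher number from compound 3 to compound 4 (0.09 log units; within the scatter). A group of 10 heavy atoms thus replaces one of 5 at this position with no change beyond the scatter. The steps from the two non-aromatic groups, an at least 1.1-fold lower number from compound 2 to compound 4 (0.07 log units; that floor lies within the scatter) and an at least 1.1-fold lower number from compound 1 to compound 4 (0.07 log units; that floor lies within the scatter), give only floors, since both start from a limit: the limit of > 225000 nM in this assay, at which 2 of the 4 values shown sit.

Still open, from the compounds shown here alone, is the true size of those two steps. Also open, going by these compounds, is whether a pyridine ring, or an aromatic ring carrying an amine or a carboxylic acid, would move the number beyond the scatter.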